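Dropping the methylamino group from compound 3

The source may hold more compounds than are shown below. What is called first, only, known or untested is meant among the compounds shown, and "the series" means these compounds.

Of the compounds shown here, three built on a shared core have been measured in a functional assay on SK-BR-3 cells (Homo sapiens) for inhibition, read by CellTiter-Glo, with a stated time of 72 h; on this read-out higher numbers stand for weaker inhibition and lower numbers for stronger inhibition. Compound 1 `CNc1cc(C(N)=O)ccc1-n1nc(C(C)C)c2c(-n3cnc(-c4cnn(C)c4)c3)ccnc21` gives 419 nM. Compound 2 `CC(C)c1nn(-c2ccc(C(N)=O)c(N[C@H]3CC[C@H](O)CC3)c2)c2nccc(-n3cnc(-c4ccncc4)c3)c12`, which carries a different amino substituent and a different aromatic group, gives 165 nM. Compound 3 `CNc1cc(-n2nc(C(C)C)c3c(-n4cnc(-c5cnn(C)c5)c4)ccnc32)ccc1C(N)=O` gives 773 nM, the highest of the three numbers; it sits close to compound 1 but clearly apart from compound 2.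

Compound 4 `CC(C)c1nn(-c2ccc(C(N)=O)cc2)c2nccc(-n3cnc(-c4cnn(C)c4)c3)c12` differs from compound 3 in one place: hydrogen in place of methylamino on an aromatic carbon, ortho to a carbamoyl group. For the measured compounds named here, no measured step removes this group outright. Going by the values given here, the only step that touches it, a 1.8-fold higher number from compound 1 to compound 3 (0.27 log units; within the scatter), moves it to another position and changes little. Compound 2 differs in two places, so it says nothing direct. The change is therefore expected to move the number little, with the step of a 1.3-fold higher number from compound 3 to compound 4 (0.11 log units; within the scatter) taken as the best guess. Compound 4 is estimated at 1000 nM, within a range of 300 nM to 3500 nM.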

Compound 4, half-maximal inhibitory concentration: 1640 nM
The estimate for compound 4 lay 1.6-fold (0.21 log units) below the measured number; low and high end bracket the measured number.
By their numbers in this assay, from the lowest: compound 2; then compounds 1 and 3 (each within the scatter of the next); then compound 4.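

In this assay, removing the methylamino group has a measurable cost: the step is a 2.1-fold higher number from compound 3 to compound 4 (0.33 log units; beyond the scatter), and removing it from the 4-carbamoyl-2-(methylamino)phenyl group of compound 1 gives a 3.9-fold higher number from compound 1 to compound 4 (0.59 log units; beyond the scatter). Moving the group had shown only a 1.8-fold higher number from compound 1 to compound 3 (0.27 log units; within the scatter), so these two removals show what that step could not: inhibition is weaker without methylamino than with it at either of the two places, although both steps are modest. Nothing measured here explains why the group makes this difference.

Still open, on these data alone, is whether a plain amine, a methoxy group or a longer aminoalkyl chain at this place would match methylamino. Compound 2 carries a different amino substituent, but it also has a second change, so it cannot settle the question.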